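A few compounds are considered here, and "the series" means these few. Any claim that something is new, unique, unknown or untested is made for them only; others in the source may bear on it.

Of the compounds shown here, three have been measured in a functional assay on HepG2 cells (Homo sapiens) for antiproliferative activity, read by CCK-8 assay, with a stated time of 72 h; a higher number here means a weaker inhibitor, a lower number a stronger inhibitor. Compound 1 `O=C(/C=C/c1ccc(COc2ccccc2)cc1)NO` gives 8400 nM, the lowest of the three numbers. Compound 2 `O=C(NO)c1ccc(COc2ccccc2)cc1` gives 29600 nM, and the single-point change between them, a 3.5-fold higher number from compound 1 to compound 2 (0.55 log units; beyond the scatter), was a modest step. Compound 3 `Nc1ccccc1NC(=O)c1ccc(CN2CCc3cc(Br)ccc32)cc1`, which carries a different tail on the shared core, gives 10700 nM; its gap to compound 1 is within the scatter, so no order between them can be read.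

Compound 4 `Nc1ccccc1NC(=O)/C=C/c1ccc(COc2ccccc2)cc1` keeps the whole of compound 1 except for one change: 2-aminophenyl in place of hydroxy on an amide-type nitrogen. Within the data shown here, no measured pair isolates this change. Among the measured compounds shown here, the only bearing comes from compound 3, which also carries a (2-aminophenyl)amino group on its carbonyl and lands close to compound 1: in this assay compound 3 gives 10700 nM. The step from compound 1 to compound 4 is therefore expected to be small, a 1.2-fold higher number from compound 1 to compound 4 (0.08 log units; within the scatter), in either direction and likely within the scatter. In this assay compound 4 is estimated at 10000 nM, with a range from 3000 nM to 35000 nM.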

Compound 4, half-maximal inhibitory concentration: > 32000 nM
Compound 4 gave a limit, no number; the forecaster's own chance of this, stated with the estimate: 5%; at least 3.2-fold (0.50 log units) between middle value and limit.
By their numbers in this assay, from the lowest: compounds 1 and 3 (each within the scatter of the next); then compound 2. At a limit, above all of these: compound 4.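

Compound 4 is the first compound shown in which the group on the amide-type nitrogen changes while the rest of compound 1 stays the same, and this position proves sensitive to that change. In this assay, putting 2-aminophenyl in place of hydroxy gives an at least 3.8-fold higher number from compound 1 to compound 4 (0.58 log units; beyond the scatter), so on this scaffold the larger group does not match hydroxy and the inhibitor is weaker. Compound 4 gives a limit and not a number: the limit of > 32000 nM in this assay, at which 1 of the 4 values shown sits.

On these data alone, how much weaker compound 4 really is therefore stays open, since only a minimum for the step can be read. Also open, as far as these compounds go, is whether a smaller group on this nitrogen, such as methoxy, or a plain phenyl ring without the amino group would keep the activity of compound 1.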